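Trimethoxyphenyl Variation of a Semicarbazone Kinase-Like Series

A few compounds are considered here, and "the series" means these few. Any claim that something is new, unique, unknown or untested is made for them only; others in the source may bear on it.

Of the compounds shown here, three sharing one core have been tested in a functional assay on U-87MG ATCC cells (Homo sapiens) for cytotoxicity, read by MTT assay, with a stated time of 72 h; a higher number here means a weaker inhibitor, a lower number a stronger inhibitor. Compound 1 `CN(C)CCn1cnnc1-c1cc(Oc2ccc(NC(=O)N/N=C/c3ccc(Cl)cc3)cc2F)ccn1` gives 1370 nM. Compound 2 `CN(C)CCn1cnnc1-c1cc(Oc2ccc(NC(=O)N/N=C/c3ccc(O)c(Br)c3)cc2F)ccn1` gives 12400 nM, and compound 3 `COc1ccc(/C=N/NC(=O)Nc2ccc(Oc3ccnc(-c4nncn4CCN(C)C)c3)c(F)c2)c(OC)c1` gives 12600 nM. Among these three numbers compound 2 sits second highest: its nearest neighbour is compound 3, with a 1.0-fold higher number from compound 2 to compound 3 (0.01 log units; within the scatter), while compound 1 lies furthest off, with a 9.1-fold higher number from compound 1 to compound 2 (0.96 log units; beyond the scatter).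

The next compound, compound 4 `COc1cc(/C=N/NC(=O)Nc2ccc(Oc3ccnc(-c4nncn4CCN(C)C)c3)c(F)c2)cc(OC)c1OC`, differs from compound 2 in one place: 3,4,5-trimethoxyphenyl in place of 3-bromo-4-hydroxyphenyl on a carbon with a double bond to nitrogen. Two earlier steps bear on this. The move to a methoxy-bearing ring in a 9.2-fold higher number from compound 1 to compound 3 (0.96 log units; beyond the scatter) cost a modest amount against the chlorophenyl parent, but between the two oxygen-bearing rings the step of a 1.0-fold higher number from compound 2 to compound 3 (0.01 log units; within the scatter) stayed within the scatter. A third methoxy group is therefore expected to leave the number about where compound 2 and compound 3 already sit, with an estimated 1.1-fold higher number from compound 2 to compound 4 (0.05 log units; within the scatter). Compound 4 is estimated at 14000 nM, within a range from 5000 nM to 40000 nM.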

Compound 4, half-maximal inhibitory concentration: 22500 nM
Compound 4: the middle estimate sits 1.6-fold (0.21 log units) below what was measured; measured number inside the range.
By their numbers in this assay, from the lowest: compound 1; then compounds 2, 3 and 4 (each within the scatter of the next).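

Swapping the 3-bromo-4-hydroxyphenyl or the 2,4-dimethoxyphenyl ring for 3,4,5-trimethoxyphenyl does not separate compound 4 from either compound in this assay: a 1.8-fold higher number from compound 2 to compound 4 (0.26 log units; within the scatter) and a 1.8-fold higher number from compound 3 to compound 4 (0.25 log units; within the scatter) both stay within the usual scatter, so three differently decorated oxygen-bearing rings cannot be told apart here. Among these compounds, compound 1 remains apart from all three, and a 16-fold higher number from compound 1 to compound 4 (1.22 log units; beyond the scatter) is the first step at this position printed as large. No measurement is available that explains these numbers.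

As far as these compounds go, it remains open whether the lower number of compound 1 belongs to the chlorine itself or to the lack of oxygen on its ring. A plain phenyl, 4-bromophenyl or 4-methoxyphenyl ring at the same carbon would help separate these two readings.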